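From a Nitrile to an Ether on the Chain

A few compounds are considered here, and "the series" means these few. Any claim that something is new, unique, unknown or untested is made for them only; others in the source may bear on it.

Measured so far:
- compound 1, `C=CCCn1c(=O)c2[nH]cnc2n(CCC)c1=O`, 60 nM
- compound 2, `CCCn1c(=O)n(C)c(=O)c2c1ncn2CC#N`, 6600 nM

In an assay on Cerebral cortex for binding affinity to adenosine receptor A1 (Cavia porcellus), read by radioligand binding (on this read-out higher numbers stand for weaker inhibition and lower numbers for stronger inhibition), compound 2 gives the higher of the two numbers, while compound 1 gives 60 nM. The gap between these two values lies beyond the usual scatter, so compound 2 is the weaker binder of the pair.

Compound 3, `CCCn1c(=O)n(C)c(=O)c2c1ncn2CCOCC`, has not been measured. It differs from compound 2 in one place: ethoxymethyl in place of cyano on a saturated chain carbon bound to an aromatic nitrogen. Among the compounds with values here, no pair of measured compounds differs by exactly this change, so the size of the step has to be guessed. The number for compound 3 is expected to move downward, toward the value of compound 1, by a step beyond the scatter, written as a 4.4-fold lower number from compound 2 to compound 3 (0.64 log units; beyond the scatter). The estimate for compound 3 in this assay is 1500 nM, with a range from 400 nM to 6000 nM.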

Compound 3, inhibition constant: 24300 nM
Estimate against measurement, compound 3: 16-fold (1.21 log units) below, and the stated range ends below it.
By their numbers in this assay, from the lowest: compound 1; then compound 2; then compound 3.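

Replacing cyano with ethoxymethyl on a saturated chain carbon bound to an aromatic nitrogen gives, in this assay, a 3.7-fold higher number from compound 2 to compound 3 (0.57 log units; beyond the scatter), so this position responds to the change and the larger group here goes with weaker binding. Both groups carry no hydrogen-bond donors and one hydrogen-bond acceptor, so matching these counts did not keep the two numbers together. Nothing shown here gives a reason for the step.

Within the data shown here, with only this one step at the position, it remains open whether the rise follows the greater length of the chain or the oxygen within it. A plain butyl chain at this place could separate those two readings, while an amine or a carboxylic acid there would show how far other groups move the number.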